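A Nitrobenzyl Group in Place of Allyl on the Amine

This account rests on a few compounds, and the source may have more. Where it says the series, first, only, none or still open, it means among the compounds named here.

Of the compounds shown here, three sharing one core have been measured in an assay on cells for displacement of a labelled ligand from corticotropin-releasing factor receptor 1 (Homo sapiens), with a stated time of 100 min; on this read-out higher numbers stand for weaker inhibition and lower numbers for stronger inhibition. Compound 1 `CCCCN(C)Cc1c(C(F)(F)F)nc2n(-c3c(C)cc(C)cc3C)c(Cl)cn12` gives 310 nM. Compound 2 `C=CCN(CCC)Cc1c(C(F)(F)F)nc2n(-c3c(C)cc(C)cc3C)c(Cl)cn12` gives 4.5 nM, and compound 3 `C=CCN(CC=C)Cc1c(C(F)(F)F)nc2n(-c3c(C)cc(C)cc3C)c(Cl)cn12` gives 13 nM. Among these numbers compound 2 stands lowest: the step is a 69-fold lower number from compound 1 to compound 2 (1.84 log units; beyond the scatter), and the step of a 2.9-fold higher number from compound 2 to compound 3 (0.46 log units; beyond the scatter) lies beyond the scatter as well, as does a 24-fold lower number from compound 1 to compound 3 (1.38 log units; beyond the scatter).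

Compound 4 `CCCN(Cc1ccc([N+](=O)[O-])cc1)Cc1c(C(F)(F)F)nc2n(-c3c(C)cc(C)cc3C)c(Cl)cn12` differs from compound 2 by 4-nitrophenyl in place of vinyl on a saturated chain carbon bound to an amine nitrogen. The measured step that bears on it most directly is a 2.9-fold higher number from compound 2 to compound 3 (0.46 log units; beyond the scatter), a modest change at the same place on the amine. The steps from compound 1 show that what hangs on this amine nitrogen can shift the number by a large amount. For the measured compounds named here, no measured step covers an aromatic ring entering at this position, so the direction is uncertain; a somewhat higher number is expected for compound 4, estimated at 20 nM, with a range from 4 nM to 120 nM, which means the expected step of a 4.4-fold higher number from compound 2 to compound 4 (0.65 log units; beyond the scatter).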

Compound 4, inhibition constant: 150 nM
For compound 4 the middle estimate is 7.5-fold (0.88 log units) below the measured one, outside the stated range (above it).
By their numbers in this assay, from the lowest: compound 2; then compound 3; then compound 4; then compound 1.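

In this assay, for the compounds shown here, the earlier steps on this amine came from small open chains, and this result adds the first aromatic ring at the position. Going from allyl to 4-nitrobenzyl gives a 33-fold higher number from compound 2 to compound 4 (1.52 log units; beyond the scatter), a large step that clearly exceeds the modest 2.9-fold higher number from compound 2 to compound 3 (0.46 log units; beyond the scatter). So this place on the amine does not accept every group equally, and a nine-atom 4-nitrophenyl group costs far more than a change between ethyl and vinyl, though nothing measured here accounts for that rise.

The change brings in the ring and the nitro group together, so the step cannot be divided between them. A plain benzyl group or a 4-aminobenzyl group on the same amine would help to separate the two, and a longer chain ending in a phenyl ring would show whether the ring's distance from the amine matters.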